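Removing the Fluorine: From Compound 3 to Compound 4

The compounds below may be only part of what the source reports. "The series", "measured", "known", "first", "only" and "open" are said of these compounds alone.

Compound 1, `Clc1ccccc1CSc1nnc(-c2ccncc2)n1-c1ccccc1`: 15700 nM
Compound 2, `Brc1ccccc1CSc1nnc(-c2ccncc2)n1-c1ccccc1`: 17100 nM
Compound 3, `Fc1ccc(CSc2nnc(-c3ccncc3)n2-c2ccccc2)cc1`: 15600 nM

In a functional assay on HepG2 cells (Homo sapiens) for inhibition, read by MTT assay, with a stated time of 48 h (a higher number here means a weaker inhibitor, a lower number a stronger inhibitor), compound 3 carries the lowest of the three numbers, yet its separation from the others is small: a 1.0-fold lower number from compound 1 to compound 3 (0.00 log units; within the scatter) and a 1.1-fold lower number from compound 2 to compound 3 (0.04 log units; within the scatter). Compound 4, `c1ccc(CSc2nnc(-c3ccncc3)n2-c2ccccc2)cc1`, differs from compound 3 by a single change: hydrogen in place of fluoro on an aromatic carbon. Every measured step bears on this, since each also alters only the halogen pattern of the benzyl group: a 1.1-fold higher number from compound 1 to compound 2 (0.04 log units; within the scatter), a 1.0-fold lower number from compound 1 to compound 3 (0.00 log units; within the scatter), a 1.1-fold lower number from compound 2 to compound 3 (0.04 log units; within the scatter). None moved the number beyond the scatter, so no step beyond the scatter is expected in this assay either. The expected step is a 1.0-fold higher number from compound 3 to compound 4 (0.01 log units; within the scatter), within the scatter. Compound 4 is accordingly estimated at 16000 nM, with a range from 8000 nM to 32000 nM.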

Compound 4, half-maximal inhibitory concentration: 12900 nM
Compound 4: the middle estimate sits 1.2-fold (0.09 log units) above what was measured, within the range that was stated.
By their numbers in this assay, from the lowest: compounds 4, 3, 1 and 2 (each within the scatter of the next).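

In this assay, taking the halogen off the benzyl group altogether left the number within the scatter: a 1.2-fold lower number from compound 3 to compound 4 (0.08 log units; within the scatter), a 1.3-fold lower number from compound 2 to compound 4 (0.12 log units; within the scatter) and a 1.2-fold lower number from compound 1 to compound 4 (0.09 log units; within the scatter). The earlier compounds shown here only exchanged one halogen pattern for another, whereas compound 4 shows that with hydrogen alone on this ring the number still cannot be told apart from those of compound 1, compound 2 and compound 3. Nothing given here accounts for this result. The compounds shown leave open whether an amine, a carboxylic acid or a methoxy group on this ring would move the number beyond the scatter.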